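A few compounds are considered here, and "the series" means these few. Any claim that something is new, unique, unknown or untested is made for them only; others in the source may bear on it.

Compound 1 `Cc1ccc(Nc2nc(N)nc(COc3ccc4c(C)cc(=O)oc4c3)n2)cc1` and compound 2 `Cc1cccc(Nc2nc(N)nc(COc3ccc4c(C)cc(=O)oc4c3)n2)c1` share one core and differ only in the methylphenyl attached to a nitrogen on an aromatic ring. In an assay on COS-7 cells for agonist activity at Free fatty acid receptor 1 (Homo sapiens), read by scintillation counting and inositol phosphate accumulation, with a stated time of 90 min (a higher number here means that more compound is needed for the effect, a lower number that less compound is needed), compound 1 gives 1790 nM, and compound 2 gives 1780 nM. On these two numbers compound 1 nominally stands highest, with compound 2 nearest, yet the step of a 1.0-fold lower number from compound 1 to compound 2 (0.00 log units; within the scatter) shows that shifting the methyl around the phenyl left the reading unchanged within the scatter. Compound 3 `CCc1cc(=O)oc2cc(OCc3nc(N)nc(Nc4ccc(C)cc4)n3)ccc12` has not been measured. Its change from compound 1 is methyl in place of hydrogen on a saturated chain carbon bound to an aromatic carbon; cut one bond further out it reads methyl to ethyl. Among the measured compounds shown here, the single measured step sits on the aryl-bound nitrogen, not on this chain, so none bears directly on the change. For the measured compounds named here, because the only available step a 1.0-fold lower number from compound 1 to compound 2 (0.00 log units; within the scatter) is flat, compound 3 is expected to show a step of a 1.0-fold higher number from compound 1 to compound 3 (0.00 log units; within the scatter), none beyond the scatter. Compound 3 is therefore estimated at 1800 nM, between 700 nM and 4500 nM.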

Compound 3, half-maximal effective concentration: 2640 nM
Estimate against measurement, compound 3: 1.5-fold (0.17 log units) below; low and high end bracket the measured number.
By their numbers in this assay, from the lowest: compounds 2, 1 and 3 (each within the scatter of the next).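

The measured series now includes a change on the saturated chain carbon bound to an aromatic carbon, a place the earlier step on the aryl-bound nitrogen did not touch. In this assay, methyl to ethyl at this place gives (  a 1.5-fold higher number from compound 1 to compound 3 (0.17 log units; within the scatter)  ), so lengthening this chain by one methyl stays within the scatter, as moving the methyl around the phenyl did. The compounds shown offer no measured explanation for this result.

As far as these compounds go, it remains open whether a longer chain, such as propyl or butyl, or a hydroxyl, an amine or a carboxylic acid on this carbon, would move the number beyond the scatter. From the compounds shown here alone, it is also open whether ethyl in place of methyl would read the same alongside the 3-methylphenyl of compound 2.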